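Adding one benzyl group to an inactive compound

A few compounds are considered here, and "the series" means these few. Any claim that something is new, unique, unknown or untested is made for them only; others in the source may bear on it.

Compound 1 `OC[C@H]1O[C@@H](Cc2ccccc2)[C@H](O)[C@@H](OCc2ccccc2)[C@@H]1OCc1ccccc1` gives 20200 nM
Compound 2 `OC[C@H]1O[C@@H](Cc2ccccc2)[C@H](O)[C@@H](O)[C@@H]1O` gives "not active" (no number reported)

In a functional assay on HL-60 cells (Homo sapiens) for antiproliferative activity, read by MTT assay (a higher number here means a weaker inhibitor, a lower number a stronger inhibitor), compound 2 has no single number: it is reported only as "not active" (no number reported). Compound 1, by contrast, gives a measurable 20200 nM.

Compound 3 `OC[C@H]1O[C@@H](Cc2ccccc2)[C@H](O)[C@@H](O)[C@@H]1OCc1ccccc1` comes from compound 2 through one structural change: benzyl in place of hydrogen on an oxygen on a saturated carbon. Put simply, a hydroxy group becomes a benzyloxy group.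

Among the measured compounds shown here, no measured pair shows this change on its own, so any expectation is rough. For the measured compounds named here, compound 1, which also carries benzyloxy, gives 20200 nM, the only number available in this assay. The step from compound 2 is therefore expected to point towards stronger inhibition, though only as far as weak, measurable activity, and compound 3 may still yield no number. For compound 3 the estimated value is 50000 nM, with an expected range of 20000 nM to 120000 nM.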

Compound 3, half-maximal inhibitory concentration: "not active" (no number reported)
Compound 3: no number reported; the estimate stays without a comparison.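

Compound 2 and compound 3 are both reported only as not active, so no step can be read between them. Left open is whether the extra benzyloxy group of compound 1 is what goes with its measurable 20200 nM in this assay. Nothing shown here offers an explanation for this result.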